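Methoxy to dimethylamino on the aryl ring: compound 3

The source may hold more compounds than are shown below. What is called first, only, known or untested is meant among the compounds shown, and "the series" means these compounds.

Measured compounds:
- compound 1: `COc1ccc(-n2c(SCc3ccccc3)nnc2-c2cc(OC)c(OC)c(OC)c2)cc1`
- compound 2: `COc1ccc(-n2c(SCc3ccc(F)cc3)nnc2-c2cc(OC)c(OC)c(OC)c2)cc1`

Both were tested in a functional assay on HCT-116 cells (Homo sapiens) for inhibition, read by MTT assay, with a stated time of 48 h; a lower number here means a stronger inhibitor, a higher number a weaker inhibitor. Compound 1 gives 42400 nM and compound 2 gives 38700 nM. The single shown step, a 1.1-fold lower number from compound 1 to compound 2 (0.04 log units; within the scatter), involves fluoro in place of hydrogen on an aromatic carbon and lies within the scatter. Compound 2 therefore stands at the lowest of the two numbers, but only within the scatter of compound 1, so neither can be called the stronger inhibitor.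

The unmeasured compound 3 is `COc1cc(-c2nnc(SCc3ccc(F)cc3)n2-c2ccc(N(C)C)cc2)cc(OC)c1OC`. It differs from compound 2 by dimethylamino in place of methoxy on an aromatic carbon, on an aromatic carbon of a six-membered aromatic ring of carbon only. Among the compounds with values here, no measured step touches this position or exchanges one of these groups for the other; the only step known concerns a different ring. With nothing to lean on, the expectation for compound 3 is no step beyond the scatter in this assay, that is a 1.2-fold lower number from compound 2 to compound 3 (0.07 log units; within the scatter), with wide uncertainty. The estimate for compound 3 is 33000 nM, from 12000 nM to 90000 nM.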

Compound 3, half-maximal inhibitory concentration: > 60000 nM
Compound 3: no number, only a limit (the forecaster's own chance of this, stated with the estimate: 15%); middle value at least 1.8-fold (0.25 log units) from the limit.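

In this assay compound 3 gives > 60000 nM, which is a limit of the assay and not a number. Within the data shown here, this is the first change on the 4-methoxyphenyl ring, at the place para to a large group, and replacing methoxy with dimethylamino reads as an at least 1.5-fold higher number from compound 2 to compound 3 (0.19 log units; that floor lies within the scatter); since that floor lies within the scatter, a real loss of inhibition is not established, but the change brings no lower number, so this swap offers no route to a stronger inhibitor so far. Compound 3 is also the only one of the compounds shown whose reading reaches the limit, leaving the two earlier compounds as the only numbers on which further steps can be measured: the limit of > 60000 nM in this assay, at which 1 of the 3 values shown sits.

From the compounds shown here alone, how far the true value of compound 3 lies past the limit stays open, and with it the true size of the step. Also open, going by these compounds, are how a primary amine or a hydroxyl group at the same place would read in this assay, and whether dimethylamino gives the same outcome alongside the unsubstituted benzyl group of compound 1.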